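Swapping the aryl group on a thiourea nitrogen

The source may report more compounds than this note shows. Statements on the series, on what has been measured and on what is new or still open speak of the compounds shown alone.

Measured compounds:
- compound 1 `NC(=O)c1c(NC(=O)c2ccccc2Cl)sc2c1CCN(Cc1ccccc1)C2`, 14500 nM
- compound 2 `NC(=O)c1c(NC(=O)c2ccccc2Cl)sc2c1CCN(C(=S)Nc1ccccc1-c1ccccc1)C2`, 25800 nM
- compound 3 `COc1ccc(NC(=S)N2CCc3c(sc(NC(=O)c4ccccc4Cl)c3C(N)=O)C2)cc1`, 19600 nM

In a functional assay on MKN-74 cells (Homo sapiens) for antiproliferative activity, with a stated time of 24 h (on this read-out higher numbers stand for weaker inhibition and lower numbers for stronger inhibition), compound 3 gives 19600 nM, the second highest of the three numbers; its neighbours sit close, with a 1.4-fold higher number from compound 1 to compound 3 (0.13 log units; within the scatter) and a 1.3-fold lower number from compound 2 to compound 3 (0.12 log units; within the scatter). Compound 4 `NC(=O)c1c(NC(=O)c2ccccc2Cl)sc2c1CCN(C(=S)Nc1c(Cl)cccc1Cl)C2` shares the core of compound 3 and differs only by 2,6-dichlorophenyl in place of 4-methoxyphenyl on an amide-type nitrogen. Within the data shown here, the step from compound 2 to compound 3 is the one comparison that bears on this: it also exchanges one aryl group for another on the same nitrogen, and it stayed within the scatter. No change beyond the scatter is therefore expected for compound 4, that is a 1.0-fold higher number from compound 3 to compound 4 (0.01 log units; within the scatter). Compound 4 is estimated at 20000 nM, with a range from 8000 nM to 50000 nM.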

Compound 4, half-maximal inhibitory concentration: 4020 nM
Compound 4: middle estimate off by 5.0-fold (0.70 log units), on the high side, outside the stated range (below it).
By their numbers in this assay, from the lowest: compound 4; then compounds 1, 3 and 2 (each within the scatter of the next).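

On this thiourea nitrogen the aryl group can matter after all: 2,6-dichlorophenyl gives a 4.9-fold lower number from compound 3 to compound 4 (0.69 log units; beyond the scatter) and a 6.4-fold lower number from compound 2 to compound 4 (0.81 log units; beyond the scatter), although the earlier exchange of one aryl group for another stayed within the scatter. Changing the whole group on the ring amine nitrogen likewise gives a 3.6-fold lower number from compound 1 to compound 4 (0.56 log units; beyond the scatter), so this compound stands apart from all three earlier ones. No measurement shown here accounts for the difference. On these data alone, it remains open whether both chlorines are needed, and how 2-chlorophenyl, 4-chlorophenyl or 2,6-dimethylphenyl would compare on the same nitrogen.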